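The source may report more compounds than this note shows. Statements on the series, on what has been measured and on what is new or still open speak of the compounds shown alone.

Compound 1 `C=C1C[C@]23C[C@@]1(O)CC[C@H]2c1ccc(O)c(C)c1[C@@H]3Cn1cc(-c2ccccn2)nn1`: in a functional assay on SMMC-7721 cells (Homo sapiens) for cytotoxicity, read by MTT assay, with a stated time of 4 days (on this read-out lower numbers stand for stronger inhibition and higher numbers for weaker inhibition), compound 1 gives > 20000 nM, which is a limit of the assay. Compound 2 `Cc1c(O)ccc2c1[C@H](Cn1cc(-c3ccccc3)nn1)[C@@]13CC(=O)[C@@](C)(CC[C@@H]21)C3`: in this assay compound 2 gives > 20000 nM, again a limit of the assay. Compound 3 `C=C1C[C@]23C[C@@]1(O)CC[C@H]2c1ccc(OS(=O)(=O)c2ccc(C)cc2)c(C)c1[C@@H]3Cn1cc(-c2ccc(Cl)cc2)nn1`: in this assay compound 3 gives > 20000 nM, once more a limit of the assay.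

Compound 3 therefore stands at the same place as every other measured compound: it has no number of its own, only a limit, and the two further values shown are limits as well. Within the data shown here, this is the limit of > 20000 nM in this assay, at which 3 of the 3 values shown sit, so no step between measured compounds can be computed, and nothing in the numbers separates compound 3 from compound 1 or compound 2.

Compound 4 `C=C1C[C@]23C[C@@]1(O)CC[C@H]2c1ccc(OS(=O)(=O)c2ccc(C)cc2)c(C)c1[C@@H]3Cn1cc(-c2ccc(Br)cc2)nn1` has not yet been measured. It differs from compound 3 by bromo in place of chloro on an aromatic carbon, para to a large group. Among the measured compounds shown here, with no measured step in this assay to rest on, the expectation is that this exchange brings no step beyond the scatter in either direction. Compound 4 is expected to give 25000 nM, with a range from 10000 nM to 60000 nM. That estimate means a step that the limit leaves unreadable from compound 3 to compound 4, and the most probable outcome is that compound 4 is also reported only as a limit.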

Compound 4, half-maximal inhibitory concentration: > 20000 nM
Compound 4 gave a limit, no number; the forecaster's own chance of this, stated with the estimate: 85%; the middle value is on the limit's open side.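

In this assay compound 4 gives > 20000 nM, a limit of the assay and not a number, so no step can be read between compound 3 and compound 4: the limit of > 20000 nM in this assay, at which 4 of the 4 values shown sit.

The compounds shown leave open whether bromo in place of chloro alters cytotoxicity at all, and which change to the shared core would give a measurable value.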